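Phenyl in place of sec-butyl: solubility of compound 3

A few compounds are considered here, and "the series" means these few. Any claim that something is new, unique, unknown or untested is made for them only; others in the source may bear on it.

Compound 1 `C=C[C@@H]1C[C@]1(NC(=O)[C@@H]1C[C@@H](Oc2nccc3cc(OC)ccc23)CN1C(=O)[C@@H](NC(=O)N[C@@H](CC)COC)C(C)(C)C)C(=O)NS(=O)(=O)C1CC1` and compound 2 `C=C[C@@H]1C[C@]1(NC(=O)[C@@H]1C[C@@H](Oc2nccc3cc(OC)ccc23)CN1C(=O)[C@@H](NC(=O)N[C@H](COC)[C@@H](C)CC)C(C)(C)C)C(=O)NS(=O)(=O)C1CC1` share a core and differ only in the chain on the urea side. In a physicochemical assay for solubility, in phosphate buffer, at pH 6.5 (a lower number here means a less soluble compound, a higher number a more soluble compound), compound 1 gives 500 ug/mL, and compound 2 gives 326 ug/mL. Going by the values given here, the step of a 1.5-fold lower number from compound 1 to compound 2 (0.19 log units; within the scatter) is the only measured step, and compound 2 thus carries the lower of the two numbers, with compound 1 within the scatter of it.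

Compound 3 `C=C[C@@H]1C[C@]1(NC(=O)[C@@H]1C[C@@H](Oc2nccc3cc(OC)ccc23)CN1C(=O)[C@@H](NC(=O)N[C@H](COC)c1ccccc1)C(C)(C)C)C(=O)NS(=O)(=O)C1CC1` is the unmeasured member. Its change from compound 2 is phenyl in place of sec-butyl on a saturated chain carbon bound to an amide-type nitrogen and a saturated chain carbon. Among the compounds with values here, no measured step covers a ring entering at this position; the one measured step changed a saturated chain at a nearby saturated chain carbon and stayed within the scatter. The expectation for compound 3 therefore rests on that single step and on the size of the entering group alone, and a small downward move in this assay is expected, a 1.4-fold lower number from compound 2 to compound 3 (0.15 log units; within the scatter), not clearly beyond the scatter. Compound 3 is estimated at 230 ug/mL, with a range from 110 ug/mL to 480 ug/mL.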

Compound 3, solubility: 259 ug/mL
The estimate for compound 3 lay 1.1-fold (0.05 log units) below the measured number; measured number inside the range.
By their numbers in this assay, from the lowest: compounds 3, 2 and 1 (each within the scatter of the next).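

Phenyl on the saturated chain carbon bound to an amide-type nitrogen and a saturated chain carbon is the first ring shown at this position, where the earlier compounds carried only saturated chains, and in this assay the swap for sec-butyl gives a 1.3-fold lower number from compound 2 to compound 3 (0.10 log units; within the scatter) while the swap for ethyl gives a 1.9-fold lower number from compound 1 to compound 3 (0.29 log units; within the scatter) as the companion step. Both steps stay within the scatter, so the three compounds cannot be ranked in this assay, and the position has so far accepted a six-membered aromatic ring of carbon only, as well as the two saturated chains, without a step beyond the scatter. No supporting measurement is available that would explain this outcome.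

All the groups shown at this position are made of carbon only, so it remains open whether a pyridine ring, or a phenyl ring carrying an amine or a carboxylic acid, would give a step beyond the scatter. The compounds shown also leave open what a benzyl group or a longer chain would do at this carbon.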